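Chain extension on a piperidine sulfamide series against MCF7 cells

The source may hold more compounds than are shown below. What is called first, only, known or untested is meant among the compounds shown, and "the series" means these compounds.

In a functional assay on MCF7 cells (Homo sapiens) for antiproliferative activity, read by sulforhodamine B assay, with a stated time of 48 h (on this read-out higher numbers stand for weaker inhibition of growth and lower numbers for stronger inhibition of growth), compound 1, with structure `COc1ccc(-c2cc(N3CCC(CNS(N)(=O)=O)CC3)ncn2)cc1`, gives 35300 nM. Compound 3, `COc1ccc(-c2cc(N3CCC(CCNS(N)(=O)=O)CC3)ncn2)cc1`, differs from compound 1 by (sulfamoylamino)methyl in place of sulfamoylamino on a saturated chain carbon bound to a saturated ring carbon, and in this assay compound 3 gives 56600 nM; the step of a 1.6-fold higher number from compound 1 to compound 3 (0.21 log units; within the scatter). Compound 2, `NS(=O)(=O)NCC1CCN(c2cc(-c3cccc4ccccc34)ncn2)CC1`, carries a different core; how its core differs from that of compound 1 is not broken down here. In this assay compound 2 gives 12100 nM, the lowest of the three numbers, and its steps to compound 1 and compound 3 lie beyond the scatter. Compound 4, `NS(=O)(=O)NCCC1CCN(c2cc(-c3cccc4ccccc34)ncn2)CC1`, differs from compound 2 by (sulfamoylamino)methyl in place of sulfamoylamino on a saturated chain carbon bound to a saturated ring carbon, the same change as from compound 1 to compound 3. On that precedent the step is expected to be small, a 1.6-fold higher number from compound 2 to compound 4 (0.20 log units; within the scatter), beside the earlier one, because the step of a 1.6-fold higher number from compound 1 to compound 3 (0.21 log units; within the scatter) stayed within the scatter. Compound 4 is therefore estimated at 19000 nM in this assay, with a likely range from 8000 nM to 45000 nM.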

Compound 4, concentration for 50% growth inhibition: 5900 nM
For compound 4 the middle estimate is 3.2-fold (0.51 log units) above the measured one, outside the stated range (below it).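

The same change did not carry over unchanged from one core to the other, giving a 2.1-fold lower number from compound 2 to compound 4 (0.31 log units; beyond the scatter) in this assay. Set beside the earlier step, the two results differ: the same change on two cores in this assay, a 1.6-fold higher number (0.21 log units; within the scatter) from compound 1 to compound 3 and a 2.1-fold lower number (0.31 log units; beyond the scatter) from compound 2 to compound 4, 3.3-fold (0.52 log units) apart, beyond the scatter of two such steps

In these two pairs, then, the outcome of the change depends on the core that carries it; this does not show what lies behind the difference, and two pairs give no rule for a further core. The compounds shown leave open whether a longer chain on the core of compound 4 would lower the number further or reverse the step. They also leave open how an amine or a carboxylic acid in place of the sulfamoylamino group would read on either core in this assay.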